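Shortening the Alkyne Side Chain on a KG-1 Antiproliferative Core

The source may report more compounds than this note shows. Statements on the series, on what has been measured and on what is new or still open speak of the compounds shown alone.

Compound 1 `COCC(C)(C)C#Cc1c(Cl)c2c(Cl)cc(C(N)=O)nc2n1[C@H]1CCCNC1`: 219 nM
Compound 2 `NC(=O)c1cc(Cl)c2c(Cl)c(C#CC3COCCO3)n([C@H]3CCCNC3)c2n1`: 77 nM; 203 nM (2 entries)

Among the compounds with values here, in a functional assay on KG-1 cells (Homo sapiens) for antiproliferative activity (on this read-out higher numbers stand for an effect only at larger amounts of compound and lower numbers for an effect already at smaller amounts), compound 1 gives 219 nM, the only compound here with a single reading, while compound 2 shows the spread seen in the several entries of compound 2 in this assay, 77 nM; 203 nM (2 entries). Compound 3 `COCCC#Cc1c(Cl)c2c(Cl)cc(C(N)=O)nc2n1[C@H]1CCCNC1` is compound 1 carrying (2-methoxyethyl in place of 1-(methoxymethyl)-1-methylethyl on a triple-bonded carbon). Within the data shown here, no two measured compounds here differ in only one place, so this step has no direct precedent among them. A step from compound 1 to compound 3 of a 1.2-fold higher number from compound 1 to compound 3 (0.07 log units; within the scatter) is expected, staying within the usual scatter. Compound 3 is therefore estimated at 260 nM, with a likely range from 100 nM to 650 nM.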

Compound 3, half-maximal effective concentration: 39 nM
For compound 3 the middle estimate is 6.7-fold (0.82 log units) above the measured one; measured number below the stated range.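

In this assay, putting 2-methoxyethyl in place of 1-(methoxymethyl)-1-methylethyl on a triple-bonded carbon gives a 5.6-fold lower number from compound 1 to compound 3 (0.75 log units; beyond the scatter), so the number in this assay depends on this chain. Both chains hold one hydrogen-bond acceptor and no ring, so the step comes with a change in the carbon skeleton, not in those counts. Single readings deserve some caution, as repeats in this assay can spread: the several entries of compound 2 in this assay, 77 nM; 203 nM (2 entries)

On these data alone, whether the chain's oxygen matters at all remains open. So does how a plain propyl chain, a longer ether chain or a terminal amine would read here.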